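Fluoro in place of nitro: compound 2 to compound 3

A few compounds are considered here, and "the series" means these few. Any claim that something is new, unique, unknown or untested is made for them only; others in the source may bear on it.

Of the compounds shown here, two have numbers so far in a functional assay on SK-OV-3 cells (Homo sapiens) for cytotoxicity, read by spectrophotometry, with a stated time of 72 h; on this read-out higher numbers stand for weaker inhibition and lower numbers for stronger inhibition. Compound 1 (`COc1ccc(-c2cccc(=O)n2-c2cc(OC)c(OC)c(OC)c2)cc1OCc1ccccc1`) gives 2310 nM. Compound 2 (`COc1cc(-c2cccc(=O)n2-c2ccc([N+](=O)[O-])cc2)cc(OC)c1OC`) gives 311 nM, the lowest of the two numbers, and the gap to compound 1 lies beyond the scatter. Within the data shown here, no step between these two compounds isolates a change in one place, so the series holds no direct measure of any single exchange.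

Compound 3 (`COc1cc(-c2cccc(=O)n2-c2ccc(F)cc2)cc(OC)c1OC`) has fluoro in place of nitro on an aromatic carbon, para to a large group: fluoro in place of nitro on an aromatic carbon. Among the measured compounds shown here, no measured pair tests this exchange. The expectation therefore rests only on compound 2 at 311 nM, the lower end of the numbers seen so far, from which a move toward a higher number in this assay is more likely than a further fall. A moderate change is expected, and a result within the scatter remains possible. The expected size is an estimated 1.9-fold higher number from compound 2 to compound 3 (0.29 log units; within the scatter). For compound 3 the estimated value is 600 nM, with an expected range of 150 nM to 2400 nM.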

Compound 3, half-maximal inhibitory concentration: 9740 nM
Compound 3: the middle estimate sits 16-fold (1.21 log units) below what was measured; the whole stated range lies below it.
By their numbers in this assay, from the lowest: compound 2; then compound 1; then compound 3.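

In this assay, the series now has its only direct measure of a single exchange: fluoro in place of nitro, on an aromatic carbon para to a large group, gives a 31-fold higher number from compound 2 to compound 3 (1.50 log units; beyond the scatter). With the rest of the structure held constant, this position is clearly not indifferent to its substituent, since 4-nitrophenyl and 4-fluorophenyl give results far apart and the step lies well beyond the scatter. No measurement shown here accounts for this step, so the pair records its size and direction but not its origin.

Among these compounds, the single pair cannot separate how much of the step is specific to nitro from how much is specific to fluoro, and an amine, a nitrile or a carboxylic acid at this same place would help to show where other groups fall between or beyond these two results. On these data alone, it also remains open whether the exchange would give a step of similar size with other groups on the remainder of the shared core, as one pair on one background supports no general rule for the series.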